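Bromo in place of hydrogen: the step to compound 4

The source may report more compounds than this note shows. Statements on the series, on what has been measured and on what is new or still open speak of the compounds shown alone.

Measured compounds and their values:
- compound 1 `O=C1CC(c2cccc(Cl)c2)n2ncnc2N1`: 47.3 mg/kg
- compound 2 `O=C1CC(c2ccccc2Br)n2ncnc2N1`: 19.7 mg/kg
- compound 3 `O=C1CC(c2ccccc2)n2nccc2N1`: 47.3 mg/kg

All three were tested in a functional assay on the whole organism (strain Kunming) with Mus musculus as the target; on this read-out higher numbers stand for an effect only at larger amounts of compound and lower numbers for an effect already at smaller amounts. Compound 3 gives 47.3 mg/kg in this assay, level with compound 1 at the digits shown, and together these two stand at the highest number of the three. Compound 2 differs from compound 3 in several places. In this assay compound 2 gives 19.7 mg/kg, a lower number that lies beyond the scatter.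

Compound 4 `O=C1CC(c2ccccc2Br)n2nccc2N1` is the next compound to be measured in this assay. It differs from compound 3 in a single respect: bromo in place of hydrogen on an aromatic carbon. The shared core of compound 3 is kept unchanged.

Within the data shown here, no single step with this exact change has been measured, so the expectation rests on what is at hand. Compound 2 carries the same bromo group and gives 19.7 mg/kg, a lower number than compound 1 and compound 3, although its core also differs. A moderate move toward a lower number is therefore expected for compound 4, with real uncertainty in its size. The estimated step of a 1.9-fold lower number from compound 3 to compound 4 (0.28 log units; within the scatter) is expected to go beyond the scatter but not by much. For compound 4 the estimate in this assay is 25 mg/kg, with a range from 10 mg/kg to 60 mg/kg.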

Compound 4, dose for half-maximal effect: 39.4 mg/kg
Estimate against measurement, compound 4: 1.6-fold (0.20 log units) below; the measured number falls inside the stated range.
By their numbers in this assay, from the lowest: compounds 2, 4, 1 and 3 (each within the scatter of the next, the first and the last beyond it).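

In this assay, among these compounds, the step that changes only this one group reads a 1.2-fold lower number from compound 3 to compound 4 (0.08 log units; within the scatter), so the two compounds stand within the scatter of each other and bromo on this aromatic carbon, ortho to a large group, shows no clear effect on the shared core of compound 3. Among the compounds shown here, this is the first clean view of the group, since the earlier bromo compound, compound 2, also differed from compound 3 in several other places and so could not show what bromo does by itself. Nothing at hand explains why the step is this small, and no measurement of any property of these compounds bears on it.

What the same bromo step would do on the core of compound 2 stays open, as the compounds shown offer no partner for compound 2 that differs from it by this group alone. As far as these compounds go, it is also open whether this carbon accepts other groups as readily, for example an amine, a methoxy group or a carboxylic acid, since a single bromo result cannot speak for groups of a different kind.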